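Amide nitrogen substituent, compound 3 to compound 4

The source may hold more compounds than are shown below. What is called first, only, known or untested is meant among the compounds shown, and "the series" means these compounds.

The series shares the core seen in compound 1 `CSCC[C@H](NC(=O)c1ccc(NCc2cncn2Cc2cccc(C)c2)cc1-c1ccccc1)C(=O)O`, compound 2 `CSCC[C@H](NC(=O)c1ccc(NCc2cncn2Cc2ccccc2C)cc1-c1ccccc1)C(=O)O` and compound 3 `CC(C)NC(=O)c1ccc(NCc2cncn2Cc2ccc(C#N)cc2)cc1-c1ccccc1`. In a functional assay on NIH3T3 cells (Mus musculus) (on this read-out lower numbers stand for an effect already at smaller amounts and higher numbers for an effect only at larger amounts of compound), compound 1 reaches only the limit > 10 uM. Compound 2 likewise stops at the limit > 10 uM in this assay. Going by the values given here, the single measured step, a step that the two limits leave unreadable from compound 1 to compound 2, therefore cannot be read for size or direction. Compound 3 also gives only the limit > 10 uM in this assay. All three measured compounds thus stand at the same place, namely (the limit of > 10 uM in this assay, at which 3 of the 3 values shown sit).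

Compound 4 `N#Cc1ccc(Cn2cncc2CNc2ccc(C(=O)NCc3ccccc3)c(-c3ccccc3)c2)cc1` differs from compound 3 in one place: benzyl in place of isopropyl on an amide-type nitrogen. Read one bond further out, isopropylcarbamoyl becomes benzylcarbamoyl. Among the compounds with values here, no measured step touches the amide nitrogen substituent, and the one step between measured compounds is unreadable, so the measured data give no basis for expecting a shift beyond the scatter in this assay in either direction. The expected step that the limit leaves unreadable from compound 3 to compound 4 is accordingly taken as small. Compound 4 is estimated at 15 uM, within a range of 3 uM to 60 uM, with a substantial chance that the readout again ends at the limit.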

Compound 4, concentration for half-maximal effect: > 10 uM
Compound 4: only a limit was reported; the forecaster's own chance of this, stated with the estimate: 65%; the middle value is on the limit's open side.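

Compound 3 and compound 4 both end at a limit in this assay, and the step between them, benzyl in place of isopropyl on an amide-type nitrogen, cannot be read for size or direction. The compounds shown leave open whether either change, at the amide nitrogen or between 3-methylphenyl and 2-methylphenyl, alters the read-out at all, with every reading at one place: the limit of > 10 uM in this assay, at which 4 of the 4 values shown sit.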